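The source may hold more compounds than are shown below. What is called first, only, known or untested is meant among the compounds shown, and "the series" means these compounds.

Compound 1 `CCOC(=O)c1cc(-c2cccc(OCc3cccc([N+](=O)[O-])c3)c2)on1` was examined in an ADME assay on Vero cells (Chlorocebus sabaeus) for cytotoxicity, with a stated time of 72 h; on this read-out lower numbers stand for stronger inhibition and higher numbers for weaker inhibition. In this assay compound 1 gives > 128000 nM, which is a limit of the assay and not a number. Compound 2 `CCOC(=O)c1cc(-c2cccc(OCc3ccccc3C(F)(F)F)c2)on1` likewise reaches only a limit in this assay, at > 128000 nM. Compound 3 `CCOC(=O)c1ccc(COc2cccc(-c3cc(C(=O)OCC)no3)c2)cc1` also returns a limit in this assay, at > 128000 nM. So compound 1 stands where all three measured compounds stand, at the limit of > 128000 nM in this assay, at which 3 of the 3 values shown sit, and no measured step separating two compounds is available in this series.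

Compound 4 `CCOC(=O)c1cc(-c2cccc(OCc3c(F)cccc3F)c2)on1` is the next compound to be measured in this assay. It differs from compound 1 by 2,6-difluorophenyl in place of 3-nitrophenyl on a saturated chain carbon bound to an oxygen on an aromatic ring. Since every measured compound, including compound 1, sits at the limit, the step of a number no higher from compound 1 to compound 4 (the limit leaves the size open) is expected to be none beyond the scatter, with compound 4 most likely remaining at the limit as well. Compound 4 is therefore estimated to give 128000 nM in this assay, within a range of 64000 nM to 256000 nM.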

Compound 4, half-maximal inhibitory concentration: > 128000 nM
Compound 4: no number, only a limit; the forecaster's own chance of this, stated with the estimate: 85%; the middle value sits exactly at the limit.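

In this assay compound 4 gives > 128000 nM, which is a limit of the assay and not a number. Among these compounds, compound 1 also sits at a limit, so no step between compound 1 and compound 4 can be read. The compounds shown leave open whether any change on the shared core would bring this read-out to a measurable number.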